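Replacing 4-iodophenyl with 3-methoxyphenyl on a shared core

This account rests on a few compounds, and the source may have more. Where it says the series, first, only, none or still open, it means among the compounds named here.

Of the compounds shown here, three built on one shared core have been measured in a functional assay on A549 cells (Homo sapiens) for cytotoxicity, read by MTT assay, with a stated time of 48 h; a higher number here means a weaker inhibitor, a lower number a stronger inhibitor. Compound 1 `C=C1CCC[C@]2(C)CCC(c3cn(-c4ccc(C(C)=O)cc4)nn3)=CC[C@@]12C` gives 46400 nM, and compound 2 `C=C1CCC[C@]2(C)CCC(c3cn(-c4cccc([N+](=O)[O-])c4)nn3)=CC[C@@]12C` gives 24700 nM. Between these two lies a 1.9-fold lower number from compound 1 to compound 2 (0.27 log units; within the scatter). Compound 3 `C=C1CCC[C@]2(C)CCC(c3cn(-c4ccc(I)cc4)nn3)=CC[C@@]12C` gives 137000 nM, the highest number of the three, which makes it the weakest inhibitor here.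

Compound 4 `C=C1CCC[C@]2(C)CCC(c3cn(-c4cccc(OC)c4)nn3)=CC[C@@]12C` is still unmeasured. Its difference from compound 3 is 3-methoxyphenyl in place of 4-iodophenyl on an aromatic nitrogen, with 3-methoxyphenyl in place of 4-iodophenyl on an aromatic nitrogen. For the measured compounds named here, two measured steps bear on this swap, a 3.0-fold higher number from compound 1 to compound 3 (0.47 log units; beyond the scatter) and a 5.5-fold higher number from compound 2 to compound 3 (0.74 log units; beyond the scatter). Both are modest, and both show the 4-iodophenyl compound with the higher number. Going by the values given here, no measured compound carries a methoxy group, so this is only a rough guide.

A modest drop in the number is therefore expected, and the estimated step is a 2.7-fold lower number from compound 3 to compound 4 (0.44 log units; beyond the scatter). For compound 4 the estimated value in this assay is 50000 nM, with an expected range of 18000 nM to 130000 nM.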

Compound 4, half-maximal inhibitory concentration: 11200 nM
Compound 4: the middle estimate sits 4.5-fold (0.65 log units) above what was measured; measured number below the stated range.
By their numbers in this assay, from the lowest: compound 4; then compounds 2 and 1 (each within the scatter of the next); then compound 3.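

Across the four compounds in this assay, compound 4 has the lowest number, and every step to it lies beyond the scatter (a 12-fold lower number from compound 3 to compound 4 (1.09 log units; beyond the scatter); a 2.2-fold lower number from compound 2 to compound 4 (0.34 log units; beyond the scatter); a 4.1-fold lower number from compound 1 to compound 4 (0.62 log units; beyond the scatter)). The group on the aromatic nitrogen can therefore shift this number by a large amount, more than any earlier step showed, and the methoxy group also separates itself from the nitro group within the 3-substituted phenyl pair. Nothing available explains why the methoxy compound gives the lowest number.

The names 4-iodophenyl and 3-methoxyphenyl differ in both the group and its number on the phenyl ring, so the largest step cannot separate those two changes. From the compounds shown here alone, whether the methoxy group itself matters also stays open, and a 4-methoxyphenyl, 3-hydroxyphenyl or 3-aminophenyl group would help to settle it.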